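The source may hold more compounds than are shown below. What is called first, only, known or untested is meant among the compounds shown, and "the series" means these compounds.

Compound 1 `COc1ccc(C)cc1N1C(=O)CSC1c1cccc(C(=O)NCCCCc2ccccc2)c1` gives 92% in a functional assay on MG-63 cells (Homo sapiens) for inhibition, read by CCK-8 assay, with a stated time of 72 h, tested at 1 uM; on this read-out lower numbers stand for less inhibition and higher numbers for more inhibition at the one concentration tested (going by the name of the read-out); compound 2 `Cc1cccc(N2C(=O)CSC2c2cccc(C(=O)NCCCCc3ccccc3)c2)c1` gives 93% in this assay.

Of these two numbers compound 1 sits at the lower one, yet the step of a number 1 percentage points higher from compound 1 to compound 2 (within the scatter) does not separate the two compounds. Compound 3 `O=C(NCCCCc1ccccc1)c1cccc(C2SCC(=O)N2c2ccccc2F)c1` differs from compound 1 by 2-fluorophenyl in place of 2-methoxy-5-methylphenyl on an amide-type nitrogen in a ring. For the measured compounds named here, the one measured step, a number 1 percentage points higher from compound 1 to compound 2 (within the scatter), concerns only a methoxy on an aromatic carbon and stayed within the scatter; no measured step swaps the whole aryl group, so the expectation for compound 3 rests on a loose footing. Compound 3 is expected to land close to compound 1, a number 6 percentage points lower from compound 1 to compound 3 (within the scatter). The estimate for compound 3 in this assay is 86%, with a range from 70% to 97%.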

Compound 3, a percentage reported as inhibition, at one concentration (the size of the read-out at that concentration, not a potency): 92%
Beside the measured number, compound 3's estimate is 6 percentage points below it; low and high end bracket the measured number.
By their numbers in this assay, from the lowest: compounds 1, 3 and 2 (each within the scatter of the next).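

Replacing the whole aryl group on the amide-type nitrogen in a ring does not separate the compounds: 2-fluorophenyl in place of 2-methoxy-5-methylphenyl gives no change at the digits printed from compound 1 to compound 3 (within the scatter), and in place of 3-methylphenyl it gives a number 1 percentage points lower from compound 2 to compound 3 (within the scatter). The earlier pair spoke only to a methoxy, whereas here a smaller aryl group carrying fluorine leaves this assay unmoved. No evidence at hand bears on this result.

Going by these compounds, whether an amine or a carboxylic acid on this phenyl ring would hold the number stays open. So does how these compounds would compare at lower concentrations.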